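This account rests on a few compounds, and the source may have more. Where it says the series, first, only, none or still open, it means among the compounds named here.

Compound 1 `COc1cc(-c2cc(/C=C/C(=O)c3ccc(N)cc3)[nH]n2)cc(OC)c1OC` gives 3670 nM in a functional assay on ACHN cells (Homo sapiens) for inhibition, read by sulforhodamine B assay, with a stated time of 48 h (a lower number here means a stronger inhibitor of growth, a higher number a weaker inhibitor of growth), the lowest of the two numbers measured here. Compound 2 `COc1ccc(-c2cc(/C=C/C(=O)c3ccc(OC)c(OC)c3)[nH]n2)cc1` gives 3830 nM, which lies within the scatter of compound 1. Compound 3 `COc1cc(-c2cc(/C=C/C(=O)c3ccc(Cl)c(Cl)c3)[nH]n2)cc(OC)c1OC` reaches only the limit > 100000 nM, so its value is a limit and not a number (the limit of > 100000 nM in this assay, at which 1 of the 3 values shown sits). Among the measured compounds shown here, the single measured step, an at least 27-fold higher number from compound 1 to compound 3 (1.43 log units; beyond the scatter), concerns the group on the carbonyl carbon. Compound 4 `COc1ccc(-c2cc(/C=C/C(=O)c3ccc(N)cc3)[nH]n2)cc1OC` differs from compound 1 in another way: hydrogen in place of methoxy on an aromatic carbon, on an aromatic carbon of a six-membered aromatic ring of carbon only, ortho to a methoxy group and meta to a large group. For the measured compounds named here, no measured step covers this exact change, so the expected step of a 1.2-fold higher number from compound 1 to compound 4 (0.09 log units; within the scatter) is small. Compound 4 is therefore estimated at 4500 nM, within 1500 nM to 15000 nM.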

Compound 4, concentration for total growth inhibition: 3290 nM
Compound 4: middle estimate off by 1.4-fold (0.14 log units), on the high side, within the range that was stated.
By their numbers in this assay, from the lowest: compounds 4, 1 and 2 (each within the scatter of the next). At a limit, above all of these: compound 3.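

In this assay, hydrogen in place of methoxy on this aromatic carbon, ortho to a methoxy group and meta to a large group, gives a 1.1-fold lower number from compound 1 to compound 4 (0.05 log units; within the scatter) and so this methoxy group can go without a measurable loss, at least with 4-aminophenyl on the carbonyl carbon. Nothing shown here explains why this change makes so little difference. Still open, from the compounds shown here alone, is whether an ethoxy group, a fluorine atom or an amine on this carbon would keep the number within the scatter. Also open, going by these compounds, is whether the same change would behave alike with another group on the carbonyl carbon.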